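A few compounds are considered here, and "the series" means these few. Any claim that something is new, unique, unknown or untested is made for them only; others in the source may bear on it.

Measured compounds:
compound 1 `CC1CCN(c2c(S(=O)(=O)c3cc(F)cc(F)c3)cnc3cc(Cl)ccc23)CC1` gives 94%
compound 2 `CC1CCN(c2c(S(=O)(=O)c3cc(Cl)cc(Cl)c3)cnc3cc(Cl)ccc23)CC1` gives 93%

In an assay on isolated protein for displacement of a labelled ligand from metabotropic glutamate receptor 5 (Homo sapiens), with a stated time of 60 min, tested at 1 uM (a lower number here means less inhibition, a higher number more inhibition at the concentration tested (going by the name of the read-out)), compound 1 gives 94%, and compound 2 gives 93%. For the measured compounds named here, the one step joining them, a number 1 percentage points lower from compound 1 to compound 2 (within the scatter), brought 3,5-dichlorophenyl in place of 3,5-difluorophenyl on the sulfonyl sulfur and is within the scatter; the two compounds therefore cannot be ordered against each other on these numbers. Compound 2 has the lower of the two figures, with compound 1 its nearest neighbour, though the gap between them is within the scatter.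

Compound 3 `CC1CCN(c2c(S(=O)(=O)c3ccc(Cl)c(Cl)c3)cnc3cc(Cl)ccc23)CC1` is not yet measured. It differs from compound 2 by 3,4-dichlorophenyl in place of 3,5-dichlorophenyl on a sulfonyl sulfur. Going by the values given here, no measured step moves a chlorine around the ring in this way; the only step to hand, from compound 1 to compound 2, swapped halogens at fixed positions and left the read-out essentially unchanged. Since both measured compounds sit high in this assay and the change is a rearrangement of the same atoms, compound 3 is expected to remain in the same high region, with the step of a number 5 percentage points lower from compound 2 to compound 3 (within the scatter) expected to be small. The estimate for compound 3 is 88%, ranging from 70% to 98%.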

Compound 3, a percentage reported as inhibition, at one concentration (the size of the read-out at that concentration, not a potency): 89%
Compound 3: the middle estimate sits 1 percentage points below what was measured; the measured number falls inside the stated range.
By their numbers in this assay, from the lowest: compounds 3, 2 and 1 (each within the scatter of the next).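

For the compounds shown here, compound 3 is the first in the set to alter the arrangement of the halogens rather than their identity, and the step (a number 4 percentage points lower from compound 2 to compound 3 (within the scatter)) shows that in this assay 3,4-dichlorophenyl on the sulfonyl sulfur cannot be told apart from 3,5-dichlorophenyl. The step that changes both the halogen and its arrangement (a number 5 percentage points lower from compound 1 to compound 3 (within the scatter)) cannot be told apart from no difference either, so 3,5-difluorophenyl, 3,5-dichlorophenyl and 3,4-dichlorophenyl all give figures in the same high region and cannot be ordered against one another on these numbers. Nothing measured alongside these figures bears on why the read-out stays so close across the three aryl groups.

As far as these compounds go, the three compounds all carry a dihalogenated phenyl on the sulfonyl sulfur, so it remains open whether a plain phenyl, a pyridyl or a methoxyphenyl at that place would hold the read-out in this region. From the compounds shown here alone, the figures also come from a single tested concentration and all stand high, so it remains open whether a full potency measurement would separate compounds that this read-out does not.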